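This account rests on a few compounds, and the source may have more. Where it says the series, first, only, none or still open, it means among the compounds named here.

Compound 1 `COc1ccc(/C=C(/Sc2ccc(Br)cc2)C(=O)c2ccc(Br)cc2)cc1`: 25000 nM
Compound 2 `COc1ccc(/C=C(/SCc2ccc(Cl)cc2)C(=O)c2ccc(Br)cc2)cc1`: 10000 nM
Compound 3 `COc1ccc(/C=C(/SCc2ccc(F)cc2)C(=O)c2ccc(Br)cc2)cc1`: 50000 nM

In a functional assay on DU-145 cells (Homo sapiens) for inhibition, read by trypan blue exclusion, with a stated time of 96 h (on this read-out higher numbers stand for weaker inhibition of growth and lower numbers for stronger inhibition of growth), compound 3 gives 50000 nM. The comparison with its nearest neighbour is a 2.0-fold higher number from compound 1 to compound 3 (0.30 log units; within the scatter), and the one with its furthest is a 5.0-fold higher number from compound 2 to compound 3 (0.70 log units; beyond the scatter).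

Compound 4 `O=C(/C(=C\c1ccc2ccccc2n1)SCc1ccc(F)cc1)c1ccc(Br)cc1` differs from compound 3 by quinolin-2-yl in place of 4-methoxyphenyl on a double-bonded chain carbon bound to a double-bonded chain carbon.

Going by the values given here, no measured step touches this place, since compound 1, compound 2 and compound 3 all carry 4-methoxyphenyl. Among the compounds with values here, the only guide is indirect: changes on the sulfur side gave a 2.5-fold lower number from compound 1 to compound 2 (0.40 log units; beyond the scatter) and, at the largest, a 5.0-fold higher number from compound 2 to compound 3 (0.70 log units; beyond the scatter). A step of similar modest size is therefore expected, with its direction poorly defined. The lower direction is slightly favoured, as compound 3 already has the top value of the set, 50000 nM.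

In this assay the expected move is a 2.5-fold lower number from compound 3 to compound 4 (0.40 log units; beyond the scatter).

For compound 4 the estimated value is 20000 nM, with an expected range of 4000 nM to 70000 nM.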

Compound 4, concentration for 50% growth inhibition: 25000 nM
Compound 4: middle estimate off by 1.3-fold (0.10 log units), on the low side; low and high end bracket the measured number.
By their numbers in this assay, from the lowest: compound 2; then compounds 1, 4 and 3 (each within the scatter of the next).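

In this assay, going by these compounds alone, the first change at this place, quinolin-2-yl in place of 4-methoxyphenyl on a double-bonded chain carbon bound to a double-bonded chain carbon, gives a 2.0-fold lower number from compound 3 to compound 4 (0.30 log units; within the scatter) and leaves the two compounds indistinguishable. With the 4-fluorobenzyl group on the sulfur held constant, this place therefore carries either a single carbon-only aromatic ring with its methoxy group or a two-ring group with one ring nitrogen, with no readable difference in growth inhibition. Nothing measured alongside these numbers offers an explanation for this result.

Open, as far as these compounds go, is whether the same swap also reads as flat on the 4-chlorobenzyl side, where compound 2 gives 10000 nM in this assay. Also open, from the compounds shown here alone, is how this place responds to a group without an aromatic ring, such as an amine or a carboxylic acid on a short chain.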